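This account rests on a few compounds, and the source may have more. Where it says the series, first, only, none or still open, it means among the compounds named here.

In a functional assay on DU-145 cells (Homo sapiens) for inhibition, read by WST assay, with a stated time of 3 days (a higher number here means a weaker inhibitor, a lower number a stronger inhibitor), compound 1 `CC(C)n1ccnc1/C=C/C(=O)/C=C/c1coc2ccccc2c1=O` gives 3300 nM, compound 2 `CCC(C)n1ccnc1/C=C/C(=O)/C=C/c1coc2ccccc2c1=O` gives 3300 nM, and compound 3 `CC(C)CCn1ccnc1/C=C/C(=O)/C=C/c1coc2ccccc2c1=O` gives 5800 nM. The three share one core and differ only in the group on an aromatic nitrogen. Compound 3 therefore stands within the scatter of both others, with a 1.8-fold higher number from compound 1 to compound 3 (0.24 log units; within the scatter) and a 1.8-fold higher number from compound 2 to compound 3 (0.24 log units; within the scatter). The remaining measured step is no change at the digits printed from compound 1 to compound 2 (within the scatter).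

The next compound, compound 4 `CCCC(C)n1ccnc1/C=C/C(=O)/C=C/c1coc2ccccc2c1=O`, keeps the shared core and has 1-methylbutyl in place of isopentyl on an aromatic nitrogen. The two steps that bear most directly on this change are those into compound 3, since each exchanges another group at this nitrogen for isopentyl, and neither goes beyond the scatter. By name, 1-methylbutyl is closer to the sec-butyl of compound 2, which gives 3300 nM, than to isopentyl. Among the measured compounds shown here, with only three compounds to go on, no step beyond the scatter is expected in this assay, and any small shift would be expected towards the lower number of compound 2. The expected change is a 1.5-fold lower number from compound 3 to compound 4 (0.18 log units; within the scatter). Compound 4 is estimated at 3800 nM, with an expected range from 2000 nM to 7000 nM.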

Compound 4, half-maximal inhibitory concentration: 1400 nM
Compound 4: middle estimate off by 2.7-fold (0.43 log units), on the high side; the whole stated range lies above it.
By their numbers in this assay, from the lowest: compound 4; then compounds 1, 2 and 3 (each within the scatter of the next).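

In this assay, the group on the aromatic nitrogen now produces a step beyond the scatter: isopentyl and 1-methylbutyl have the same atoms joined differently, and the exchange gives a 4.1-fold lower number from compound 3 to compound 4 (0.62 log units; beyond the scatter), so the arrangement of this chain matters here and not only its heavy-atom count. The chain also responds unevenly to extension, since a methyl in place of hydrogen two bonds along the chain gives no change at the digits printed from compound 1 to compound 2 (within the scatter), while a methyl three bonds along gives a 2.4-fold lower number from compound 2 to compound 4 (0.37 log units; beyond the scatter), and an ethyl two bonds along gives a 2.4-fold lower number from compound 1 to compound 4 (0.37 log units; beyond the scatter). All three new steps are modest, and the data shown offer no independent measurement that would explain them.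

Going by these compounds, whether the lower number continues with a longer chain such as 1-methylpentyl, or ends there, remains open, as does the outcome with a cyclopentyl ring or with a hydroxyl or an amine on the chain. On these data alone, it is also open whether the step between isopentyl and 1-methylbutyl would appear on the other cores or in other cell lines.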